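This account rests on a few compounds, and the source may have more. Where it says the series, first, only, none or still open, it means among the compounds named here.

Compound 1 `CCCOC(=O)/C=C(C)/C=C/CC(C)CCCC(C)C` is the most lipophilic of the three compounds measured in a physicochemical assay for lipophilicity (a lower number here means a more polar compound, a higher number a more lipophilic compound), where compound 1 gives 7.28. Within the data shown here, compound 3 `CCOC(=O)/C=C(C)/C=C/CC(C)CCC=C(C)C` gives 6.19 in this assay, and compound 2 `CCCOC(=O)/C=C(C)/C=C/CC(C)CCCC(C)(C)OC` gives 6.08, the only recorded step being a number 1.20 log units lower from compound 1 to compound 2 (beyond the scatter). Compound 4 `CC(/C=C/CC(C)CCCC(C)C)=C\C(=O)SC(C)C` is not yet measured; it differs from compound 1 in one place: isopropylsulfanyl in place of propoxy on a carbonyl carbon. Among the measured compounds shown here, the single recorded step concerns the methoxy in place of hydrogen on the saturated chain and does not bear on an exchange at the carbonyl carbon, so nothing here measures this change directly. He therefore expects for compound 4 a modest upward step in this assay, a number 0.42 log units higher from compound 1 to compound 4 (beyond the scatter), with the result close to the scatter. His estimate for compound 4 is 7.7, with a range from 7.2 to 8.2.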

Compound 4, partition coefficient: 8.39
Compound 4: middle estimate off by 0.69 log units, on the low side, and the stated range ends below it.
By their numbers in this assay, from the lowest: compounds 2 and 3 (each within the scatter of the next); then compound 1; then compound 4.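

The exchange at the carbonyl carbon gives a number 1.11 log units higher from compound 1 to compound 4 (beyond the scatter) in this assay, showing that this position, which the earlier step on the saturated chain did not touch, can also shift the number by a large amount, here upward. Propoxy and isopropylsulfanyl have the same counts of heavy atoms and hydrogen-bond acceptors, so those counts do not separate them. Nothing available explains the size of this step.

The compounds shown leave open whether the step follows the sulfur or the isopropyl part, a question that isopropoxy or propylsulfanyl on the same carbonyl carbon would address. As far as these compounds go, how a carboxylic acid there would read in this assay also remains open.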